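The compounds below may be only part of what the source reports. "The series", "measured", "known", "first", "only" and "open" are said of these compounds alone.

Measured so far:
Compound 1, `N#Cc1ccc2[nH]cc([C@H]3CC[C@H](NCc4ccccc4)CC3)c2c1`: 28%
Compound 2, `N#Cc1ccc2[nH]cc([C@H]3CC[C@@H](N4CCCCC4)CC3)c2c1`: 3%

In an assay on cell membranes for binding affinity to Adrenergic receptor alpha-1 (Rattus norvegicus), tested at 1 uM (a lower number here means less inhibition, a higher number more inhibition at the concentration tested (going by the name of the read-out)), compound 1 gives 28%, while compound 2 gives 3%, the lowest of the two numbers and a gap beyond the scatter. Compound 2 and compound 1 differ in more than one place, so nothing can be drawn from their pair beyond these two values.

The step under consideration leads from compound 2 to compound 3, `N#Cc1ccc2[nH]cc([C@H]3CC[C@H](N4CCCCC4)CC3)c2c1`. The change is the two compounds have the same atoms and bonds and differ only in configuration as drawn: 2 of 2 stereo elements differ (all stereocentres are inverted: mirror images); a stereocentre at a saturated ring carbon is drawn s in compound 2 and r in compound 3; a stereocentre at a saturated ring carbon is drawn s in compound 2 and r in compound 3. No step between measured compounds covers such a change, so the direction cannot be read from the numbers shown. Compound 3 shares its drawn configuration with compound 1 and its amine with compound 2, so a small rise that may well stay within the scatter is expected, estimated as a number 9 percentage points higher from compound 2 to compound 3 (within the scatter). Compound 3 is therefore estimated at 12%, with a range from 0% to 35%.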

Compound 3, a percentage reported as inhibition, at one concentration (the size of the read-out at that concentration, not a potency): 14%
For compound 3 the middle estimate is 2 percentage points below the measured one; the range from low to high includes it.
By their numbers in this assay, from the lowest: compound 2; then compound 3; then compound 1.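

With the piperidin-1-yl group held fixed, inverting both stereocentres at the saturated ring carbons gives a number 11 percentage points higher from compound 2 to compound 3 (beyond the scatter) in this assay, so drawn configuration alone shifts this read-out by a modest amount. That step can be traced to one source only: the fact that compounds 2 and 3 differ only in the configuration as drawn. With the configuration held fixed, piperidin-1-yl in place of benzylamino gives a number 14 percentage points lower from compound 1 to compound 3 (beyond the scatter), which shows that the amine on the saturated ring carbon also counts at this position.

The compounds shown leave open whether the same inversion would shift the read-out for the benzylamino compound, whose mirror image does not appear among them. They also leave open how a morpholine or a dimethylamino group on that carbon would compare in either configuration.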